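This account rests on a few compounds, and the source may have more. Where it says the series, first, only, none or still open, it means among the compounds named here.

Compound 1 `COc1ccc(CN(C(=O)CSC(=S)N2CCN(C)CC2)c2cc(OC)c(OC)c(OC)c2)cc1` gives 2640 nM

Compound 2 `CCN1CCN(C(=S)SCC(=O)N(Cc2ccc(OC)cc2)c2cc(OC)c(OC)c(OC)c2)CC1` gives 7700 nM

Compound 3 `COc1ccc(CN(C(=O)CSC(=S)N2CCN(C(=O)OC(C)(C)C)CC2)c2cc(OC)c(OC)c(OC)c2)cc1` gives 620 nM

All three were read in a functional assay on HCT-116 cells (Homo sapiens) for inhibition, read by CCK-8 assay, with a stated time of 48 h (a higher number here means a weaker inhibitor, a lower number a stronger inhibitor), and compound 2 stands highest of the three, which makes it the weakest inhibitor here, its steps to both others lying beyond the scatter. Compound 4 `COc1ccc(CN(C(=O)CSC(=S)N2CCc3ccccc32)c2cc(OC)c(OC)c(OC)c2)cc1` differs from it on the thiocarbonyl carbon (2,3-dihydro-1H-indol-1-yl in place of 4-ethylpiperazin-1-yl on a thiocarbonyl carbon). Going by the values given here, no measured step covers this exchange. The closest evidence lies in changes on the amine nitrogen in the ring: a 12-fold lower number from compound 2 to compound 3 (1.09 log units; beyond the scatter) is large, a 4.3-fold lower number from compound 1 to compound 3 (0.63 log units; beyond the scatter) is modest, and a 2.9-fold higher number from compound 1 to compound 2 (0.46 log units; beyond the scatter) is also modest but runs the other way. Among the compounds with values here, compound 4 loses the ethyl-bearing ring altogether, so a modest step to a lower number is expected in this assay even though no measured compound carries the 2,3-dihydro-1H-indol-1-yl group. The expected change is (a 4.3-fold lower number from compound 2 to compound 4 (0.63 log units; beyond the scatter)). For compound 4 the estimate is 1800 nM with an expected range from 500 nM to 6000 nM around it.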

Compound 4, half-maximal inhibitory concentration: 7710 nM
Compound 4: the middle estimate sits 4.3-fold (0.63 log units) below what was measured, and the stated range ends below it.
By their numbers in this assay, from the lowest: compound 3; then compound 1; then compounds 2 and 4 (each within the scatter of the next).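

The earlier compounds shown here changed only the group on the ring amine nitrogen, whereas compound 4 replaces the whole ring on the thiocarbonyl carbon. In this assay, 2,3-dihydro-1H-indol-1-yl in place of 4-ethylpiperazin-1-yl gives a 1.0-fold higher number from compound 2 to compound 4 (0.00 log units; within the scatter), so at this level of activity the position does not depend on keeping a piperazine ring. Set against the 4-methylpiperazin-1-yl group, the same entering group gives a 2.9-fold higher number from compound 1 to compound 4 (0.47 log units; beyond the scatter), and nothing shown explains why this exchange registers against one piperazine and not the other.

From the compounds shown here alone, it remains open whether a piperidine or morpholine ring on the thiocarbonyl carbon would read differently in this assay. Going by these compounds, it is equally open what a methoxy or chloro group on the aromatic ring of the 2,3-dihydro-1H-indol-1-yl group would do.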